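Ester Alkyl Change on a Lipophilic Dienoate

The compounds below may be only part of what the source reports. "The series", "measured", "known", "first", "only" and "open" are said of these compounds alone.

Compound 1, `CCCOC(=O)/C=C(C)/C=C/CC(C)CCCC(C)C`, gives 7.28 in a physicochemical assay for lipophilicity; a higher number here means a more lipophilic compound, a lower number a more polar compound. Compound 2, `CC#CCOC(=O)/C=C(C)/C=C/CC(C)CCCC(C)C`, gives 6.4. Compound 3, `CCCOC(=O)/C=C(C)/C=C/CC(C)CCCC(C)(C)OC`, gives 6.08.

Compound 3 thus stands lowest of the three numbers, with compound 2 nearest and compound 1 furthest: a number 1.20 log units lower from compound 1 to compound 3 (beyond the scatter). Compound 4, `COC(C)(C)CCCC(C)C/C=C/C(C)=C/C(=O)OC1CCCC1`, differs from compound 3 in one place: cyclopentyl in place of propyl on an oxygen next to a carbonyl group. Among the measured compounds shown here, the one measured step at that same place, a number 0.88 log units lower from compound 1 to compound 2 (beyond the scatter), was modest in size. Since the entering cyclopentyl brings two more carbon atoms than the propyl it replaces and no donors or acceptors, a modest step upward in this assay is expected, a number 0.62 log units higher from compound 3 to compound 4 (beyond the scatter). Compound 4 is therefore estimated at 6.7, within a range from 6.3 to 7.1.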

Compound 4, partition coefficient: 7.01
Beside the measured number, compound 4's estimate is 0.31 log units below it; measured number inside the range.
By their numbers in this assay, from the lowest: compound 3; then compound 2; then compounds 4 and 1 (each within the scatter of the next).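

In this assay, among the compounds shown here, cyclopentyl in place of propyl on an oxygen next to a carbonyl group gives a number 0.93 log units higher from compound 3 to compound 4 (beyond the scatter) and so shows that this place can move the number upward, whereas the only earlier step there, a number 0.88 log units lower from compound 1 to compound 2 (beyond the scatter), ran downward. The two steps were read on different backgrounds, as the upward one carries the methoxy group and the downward one does not. Nothing available explains the size or direction of either step. Going by these compounds, it remains open whether an open pentyl chain would match cyclopentyl at this place. On these data alone, it also remains open whether cyclopentyl would give a similar step without the methoxy group.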